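The source may report more compounds than this note shows. Statements on the series, on what has been measured and on what is new or still open speak of the compounds shown alone.

Measured compounds:
compound 1 `Cc1ccccc1CNC(=O)c1nc(-c2ccc(F)cc2)n(CC[C@@H](O)C[C@@H](O)CC(=O)O)c1C1CC1`, 4.9 nM
compound 2 `COc1ccc(CNC(=O)c2nc(-c3ccc(F)cc3)n(CC[C@@H](O)C[C@@H](O)CC(=O)O)c2C2CC2)cc1F`, 3.7 nM
compound 3 `Cc1ccc(CNC(=O)c2nc(-c3ccc(F)cc3)n(CC[C@@H](O)C[C@@H](O)CC(=O)O)c2C2CC2)cc1`, 1.7 nM

All three share one core and differ only in the aromatic ring that sits on a saturated chain carbon bound to an amide-type nitrogen. In an assay on microsomes from liver for inhibition of 3-hydroxy-3-methylglutaryl-coenzyme A reductase (Rattus norvegicus), read by scintillation counting, with stated times of 0.5 h and 0.75 h (a lower number here means a stronger inhibitor, a higher number a weaker inhibitor), compound 3 gives the lowest of the three numbers. Its margin over compound 2 is a 2.2-fold lower number from compound 2 to compound 3 (0.34 log units; beyond the scatter), and over compound 1 it is a 2.9-fold lower number from compound 1 to compound 3 (0.46 log units; beyond the scatter), both modest but beyond the scatter. Between compound 1 and compound 2 the step is a 1.3-fold lower number from compound 1 to compound 2 (0.12 log units; within the scatter), so those two cannot be told apart.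

Compound 4 `O=C(O)C[C@H](O)C[C@H](O)CCn1c(-c2ccc(F)cc2)nc(C(=O)NCc2ccc(F)c(F)c2)c1C1CC1` is the next step from compound 3: 3,4-difluorophenyl in place of 4-methylphenyl on a saturated chain carbon bound to an amide-type nitrogen. Going by the values given here, two measured steps bear on it. The 4-methylphenyl ring of compound 3 beat a 3-fluoro-4-methoxyphenyl ring, which also carries a fluorine and a second substituent on the same ring, by a 2.2-fold lower number from compound 2 to compound 3 (0.34 log units; beyond the scatter), and it beat a 2-methylphenyl ring by a 2.9-fold lower number from compound 1 to compound 3 (0.46 log units; beyond the scatter). Replacing it with 3,4-difluorophenyl is therefore expected to give a modestly higher number, the estimated step from compound 3 to compound 4 being a 2.1-fold higher number from compound 3 to compound 4 (0.31 log units; beyond the scatter) in this assay. Compound 4 is thus expected at about 3.5 nM, within a range of 1.5 nM to 8 nM.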

Compound 4, half-maximal inhibitory concentration: 1.2 nM
Compound 4: the middle estimate sits 2.9-fold (0.46 log units) above what was measured; measured number below the stated range.
By their numbers in this assay, from the lowest: compounds 4 and 3 (each within the scatter of the next); then compounds 2 and 1 (each within the scatter of the next).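

In this assay, 3,4-difluorophenyl in place of 4-methylphenyl on a saturated chain carbon bound to an amide-type nitrogen gives a 1.4-fold lower number from compound 3 to compound 4 (0.15 log units; within the scatter), so these two compounds cannot be told apart and this position tolerates two fluorines as well as one methyl group. Against the other rings the new one keeps the same standing as the 4-methylphenyl ring: fluoro in place of methoxy on an aromatic carbon gives a 3.1-fold lower number from compound 2 to compound 4 (0.49 log units; beyond the scatter), and 3,4-difluorophenyl in place of 2-methylphenyl gives a 4.1-fold lower number from compound 1 to compound 4 (0.61 log units; beyond the scatter), both modest steps but beyond the scatter. Nothing available explains why these rings rank as they do.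

Still open, on these data alone, is what each fluorine contributes on its own, which a 3-fluorophenyl or a 4-fluorophenyl ring would help to separate, and whether larger halogens such as chloro or bromo would read the same way. Also open, as far as these compounds go, is how this position would respond to a ring carrying an amine or a carboxylic acid, or to a longer chain holding the ring further out from the amide nitrogen.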